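Ester variation on the cinnamate oxygen, liver microsome half-life

The compounds below may be only part of what the source reports. "The series", "measured", "known", "first", "only" and "open" are said of these compounds alone.

Measured so far:
compound 1 `CCOc1cc(NC(=O)C2(NC(=O)c3ccc4c(C5CCCC5)c(-c5ncc(Cl)cn5)n(C)c4c3)CCC2)ccc1/C=C/C(=O)OC(=O)C[C@H](O)C(=O)O` — 7.92 h
compound 2 `CCCOC(=O)/C=C/c1ccc(NC(=O)C2(NC(=O)c3ccc4c(C5CCCC5)c(-c5ncc(Cl)cn5)n(C)c4c3)CCC2)cc1OCC` — 0.35 h

In an ADME assay (liver) for pharmacokinetics, with Liver microsome (Rattus norvegicus) as the target, using microsomes (a higher number here means that the compound lasts longer, a lower number that the compound disappears faster), compound 1 gives 7.92 h, the higher of the two numbers; compound 2 gives 0.35 h. Within the data shown here, the single measured step is a 23-fold lower number from compound 1 to compound 2 (1.35 log units; beyond the scatter), propyl in place of (2-carboxy-2-hydroxyethyl)carbonyl on an oxygen next to a carbonyl group.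

Compound 3 `CCOc1cc(NC(=O)C2(NC(=O)c3ccc4c(C5CCCC5)c(-c5ncc(Cl)cn5)n(C)c4c3)CCC2)ccc1/C=C/C(=O)OCC(=O)OC` is not yet measured. Its change from compound 1 is (methoxycarbonyl)methyl in place of (2-carboxy-2-hydroxyethyl)carbonyl on an oxygen next to a carbonyl group. This step resembles the measured one in that the (2-carboxy-2-hydroxyethyl)carbonyl of compound 1 leaves and a small acyclic group without hydrogen-bond donors enters at the same oxygen. Among the measured compounds shown here, the one relevant precedent, a 23-fold lower number from compound 1 to compound 2 (1.35 log units; beyond the scatter), was large, so a large fall in this assay is expected for compound 3 as well, though with only a single step as guide the range is wide. The expected step is a 16-fold lower number from compound 1 to compound 3 (1.20 log units; beyond the scatter). Compound 3 is thus estimated at 0.5 h, in a range from 0.15 h to 2 h.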

Compound 3, half-life: 2.08 h
Beside the measured number, compound 3's estimate is 4.2-fold (0.62 log units) below it; the whole stated range lies below it.
By their numbers in this assay, from the lowest: compound 2; then compound 3; then compound 1.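

At the oxygen next to a carbonyl group, the outcome in this assay depends on what replaces the (2-carboxy-2-hydroxyethyl)carbonyl: (methoxycarbonyl)methyl gives a 3.8-fold lower number from compound 1 to compound 3 (0.58 log units; beyond the scatter) as a modest step, whereas propyl gave the large fall (a 23-fold lower number from compound 1 to compound 2 (1.35 log units; beyond the scatter)). Among groups without hydrogen-bond donors the number still moves, with methoxycarbonyl in place of ethyl giving a 5.9-fold higher number from compound 2 to compound 3 (0.77 log units; beyond the scatter) on the saturated chain carbon bound to that oxygen. Nothing available bears on the cause of these differences.

Which feature of the (2-carboxy-2-hydroxyethyl)carbonyl keeps compound 1 highest remains open, since its two replacements differ from it in several counted features at once. Also open, going by these compounds, is how an amine, or a longer chain such as butyl, would read at this oxygen in this assay on the same core.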